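Swapping ethyl for tert-butoxy on the carbonyl of compound 2

This account rests on a few compounds, and the source may have more. Where it says the series, first, only, none or still open, it means among the compounds named here.

Compound 1 `Cc1[nH]nc(N)c1-c1ccc2ccccc2c1` — in an assay on Sf9 cells for inhibition of mitogen-activated protein kinase kinase kinase 14 (Homo sapiens), read by ADP-Glo, with a stated time of 60 min (on this read-out lower numbers stand for stronger inhibition and higher numbers for weaker inhibition), compound 1 gives > 100000 nM, which is a limit of the assay rather than a number.
Compound 2 `CCC(=O)n1nc(C)c(-c2ccc(Cl)c(Cl)c2)c1N` — in this assay compound 2 gives 27400 nM.

Within the data shown here, compound 2 therefore stands as the only compound with a numerical half-maximal inhibitory concentration; the other entry sits at the limit of > 100000 nM in this assay, at which 1 of the 2 values shown sits, so no ordering between the two can be drawn beyond that. The two compounds also differ in more than one place, so no single step can be read off between them.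

Compound 3 `Cc1nn(C(=O)OC(C)(C)C)c(N)c1-c1ccc(Cl)c(Cl)c1` is the next compound to be tested. It keeps everything in compound 2 except the group on the carbonyl, where the change is tert-butoxy in place of ethyl on a carbonyl carbon. Among the measured compounds shown here, no measured pair shows what this kind of change does in this assay, so the expectation rests on the size of the change alone: the larger group is expected to shift the value little, if at all, beyond the usual scatter, with a small drift toward weaker inhibition. The step from compound 2 to compound 3 is estimated as a 1.3-fold higher number from compound 2 to compound 3 (0.11 log units; within the scatter). Compound 3 is expected to give about 35000 nM, within a range from 9000 nM to 140000 nM.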

Compound 3, half-maximal inhibitory concentration: > 100000 nM
Compound 3 gave a limit, no number; the forecaster's own chance of this, stated with the estimate: 30%; middle value at least 2.8-fold (0.45 log units) from the limit.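

Among these compounds, this is the first readable step between two compounds that differ in one place: in this assay, tert-butoxy in place of ethyl on a carbonyl carbon gives an at least 3.6-fold higher number from compound 2 to compound 3 (0.56 log units; beyond the scatter). It shows that this place, a carbonyl carbon whose other neighbour is an aromatic nitrogen, does not accept every group equally, since the change from propanoyl to tert-butoxycarbonyl moves the result beyond the usual scatter and toward weaker inhibition. The full size of the step stays unknown, and measured numbers remain scarce in this set, with compound 3 joining compound 1 at a limit rather than a number: the limit of > 100000 nM in this assay, at which 2 of the 3 values shown sit.

The change adds carbon atoms and an oxygen at once, so the compounds shown cannot say whether the larger group, the added oxygen or both go with the weaker result. A methoxycarbonyl group at the same place, which keeps the oxygen with a smaller end, or a pivaloyl group, which keeps the branched carbons without the oxygen, would each set these two apart when compared with compound 2.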